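This account rests on a few compounds, and the source may have more. Where it says the series, first, only, none or still open, it means among the compounds named here.

Measured so far:
- compound 1 `CCCCCCCCCCc1ccc(-c2noc(CN)n2)cc1` — 62%
- compound 2 `CCCCCCCCCCc1ccc(-c2noc(CCCCN)n2)cc1` — 55%
- compound 3 `CCCCCCCCCCc1ccc(-c2noc(CC(O)CN)n2)cc1` — 59%

In an assay on HeLa cells for inhibition of sphingosine-1-phosphate transporter SPNS2 (Mus musculus), read by LC-MS, tested at 2 uM (a higher number here means more inhibition at the concentration tested (going by the name of the read-out), a lower number less inhibition), compound 1 gives 62%, the highest of the three numbers, though the gaps to the other two are not separable from scatter: a number 3 percentage points lower from compound 1 to compound 3 (within the scatter) and a number 7 percentage points lower from compound 1 to compound 2 (within the scatter). Between the other two, a number 4 percentage points higher from compound 2 to compound 3 (within the scatter).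

Compound 4 `CCCCCCCCCCc1ccc(-c2noc(CC(CN)OC(C)=O)n2)cc1` is not yet measured. It differs from compound 1 as follows: a group of 7 heavy atoms (4 carbon, 1 nitrogen, 2 oxygen; no ring) in place of one nitrogen atom, on a saturated chain carbon bound to an aromatic carbon. Every change made so far at this same place (compounds 2 and 3) left this assay essentially unmoved, all steps within the scatter. The new group is larger than either of those, but nothing measured argues for a step beyond scatter in either direction.

Compound 4 is therefore expected to give about 55% (range 40% to 70%), a step of a number 7 percentage points lower from compound 1 to compound 4 (within the scatter) that is expected to stay within scatter.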

Compound 4, a percentage reported as inhibition, at one concentration (the size of the read-out at that concentration, not a potency): 0%
Estimate against measurement, compound 4: 55 percentage points above; the whole stated range lies above it.
By their numbers in this assay, from the lowest: compound 4; then compounds 2, 3 and 1 (each within the scatter of the next).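

In this assay, going by these compounds alone, this position is not indifferent to every change: the single change of acetyl in place of hydrogen on the oxygen of compound 3 gives the step (a number 59 percentage points lower from compound 3 to compound 4 (beyond the scatter)). The steps to the same compound from the other two are also large (a number 62 percentage points lower from compound 1 to compound 4 (beyond the scatter); a number 55 percentage points lower from compound 2 to compound 4 (beyond the scatter)), whereas compounds 1, 2 and 3 all lie within the scatter of each other. No evidence bears on the cause of these steps.

The compounds shown leave open whether this outcome is specific to acetyl or extends to other groups on that oxygen, such as a methyl ether, a benzoyl ester or a carbamate.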